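Hydroxyl-to-amine swap on the side chain of compound 1

The compounds below may be only part of what the source reports. "The series", "measured", "known", "first", "only" and "open" are said of these compounds alone.

Two compounds of this series have numbers in a functional assay on OVCAR-8 cells (Homo sapiens) for antiproliferative activity; on this read-out higher numbers stand for weaker inhibition and lower numbers for stronger inhibition. Compound 1 `Cn1ncc(Cl)c1-c1cc(C(=O)N[C@@H]2CN[C@H](CCCO)C[C@H]2c2ccc(Cl)c(Cl)c2)oc1Cl` gives 600 nM in this assay, the lower of the two numbers. Compound 2 `CC(=O)NCC[C@@H]1C[C@@H](c2ccc(F)c(F)c2)[C@H](NC(=O)c2cc(-c3c(Cl)cnn3C)c(Cl)o2)CN1` gives 880 nM in this assay; its number sits within the scatter of that of compound 1, so the two are not separated. Within the data shown here, no pair of measured compounds differs in one place, so no measured step is available to anchor a prediction.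

Compound 3 `CN(C)CC[C@@H]1C[C@@H](c2ccc(Cl)c(Cl)c2)[C@H](NC(=O)c2cc(-c3c(Cl)cnn3C)c(Cl)o2)CN1` is the unmeasured analogue of compound 1. The difference between them is dimethylamino in place of hydroxymethyl on a saturated chain carbon, two bonds along the chain from a saturated ring carbon.

Nothing in the two measured numbers tells how such a change affects this assay. The step from compound 1 to compound 3 is therefore expected to stay small, and the estimate for compound 3 in this assay is 500 nM, with a range from 150 nM to 2000 nM; the expected step is a 1.2-fold lower number from compound 1 to compound 3 (0.08 log units; within the scatter), not clearly beyond the scatter in either direction.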

Compound 3, half-maximal inhibitory concentration: 1510 nM
The estimate for compound 3 lay 3.0-fold (0.48 log units) below the measured number; measured number inside the range.
By their numbers in this assay, from the lowest: compounds 1, 2 and 3 (each within the scatter of the next, the first and the last beyond it).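

In this assay this position now has its first one-place comparison: dimethylamino in place of hydroxymethyl on a saturated chain carbon, two bonds along the chain from a saturated ring carbon, gives a 2.5-fold higher number from compound 1 to compound 3 (0.40 log units; beyond the scatter) and so moves the number beyond the scatter. The position is therefore not silent to this change, although the step is modest and the 2-(dimethylamino)ethyl chain still leaves compound 3 with a measurable number. No measured evidence on hand accounts for the step.

Among these compounds, the single step does not separate the loss of the hydroxyl oxygen from the entry of the dimethylamino group as a whole. A primary amine or a methoxy group on the same saturated chain carbon would separate the two, and a carboxylic acid or a longer chain would show how far the position's response extends.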